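Serine-phosphate lipid analogues: ethoxymethyl extension of compound 3

This account rests on a few compounds, and the source may have more. Where it says the series, first, only, none or still open, it means among the compounds named here.

Measured compounds:
compound 1 `CCCCCCCC/C=C\CCCCCCCC(=O)O[C@H](C)COP(=O)(O)OC[C@H](N)C(=O)O` — 11.4%
compound 2 `CCCCCCCC/C=C\CCCCCCCC(=O)O[C@@H](C)COP(=O)(O)OC[C@H](N)C(=O)O` — 11.6%
compound 3 `C[C@H](COC(=O)CCc1ccccc1OCc1cccc(Oc2ccccc2)c1)OP(=O)(O)OC[C@H](N)C(=O)O` — 13.2%

In an assay on HEK293 cells for agonist activity at putative P2Y purinoceptor 10 (Mus musculus), with a stated time of 1 h (a higher number here means a larger maximal response, a lower number a smaller maximal response), compound 1 gives 11.4%, compound 2 gives 11.6% and compound 3 gives 13.2%. Among the measured compounds shown here, the only step with a single change is a number 0.2 percentage points higher from compound 1 to compound 2 (within the scatter), which lies within the scatter; the sole evidence on it is the fact that one of compounds 1 and 2 is drawn with a defined configuration and the other without, at the place where they differ. Compound 3 has the highest of the three numbers, but its distances to compound 1 and compound 2 lie within the scatter, so no order among the three is claimed.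

Compound 4 `CCOC[C@H](COC(=O)CCc1ccccc1OCc1cccc(Oc2ccccc2)c1)OP(=O)(O)OC[C@H](N)C(=O)O` is not yet measured. It differs from compound 3 by ethoxy in place of hydrogen on a saturated chain carbon, two bonds along the chain from an oxygen on an unsaturated carbon. For the measured compounds named here, no measured step in this assay involves an ethoxy or ethoxymethyl change, so there is no direct precedent; the one measured step was within the scatter, and all three values cluster closely. On that basis the step of a number 0.8 percentage points higher from compound 3 to compound 4 (within the scatter) is expected to stay within the scatter. Compound 4 is therefore estimated at 14%, in a range from 6% to 28%.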

Compound 4, largest response reached (Emax), in percent of the reference or control that the assay uses: "not active" (no number reported)
For compound 4 the study gives words and no number, and the estimate cannot be compared.
By their numbers in this assay, from the lowest: compounds 1, 2 and 3 (each within the scatter of the next).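

Among the compounds shown here, compound 4 is reported as "not active" without a number in this assay, and no step from compound 3, at 13.2%, can be read. No available evidence bears on this result. The compounds shown leave open what methyl to ethoxymethyl does to the maximal response.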